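Propyl in Place of Cyclopropyl on a Series

The source may report more compounds than this note shows. Statements on the series, on what has been measured and on what is new or still open speak of the compounds shown alone.

In an assay on membranes from CHO cells for displacement of a labelled ligand from adenosine receptor A1 (Homo sapiens), read by scintillation counting, with a stated time of 60 min, tested at 1 uM (a higher number here means more inhibition at the concentration tested (going by the name of the read-out), a lower number less inhibition), compound 3 `CC1=C(C(=O)C2CC2)C(c2ccsc2)NC(=O)N1` gives 2%, level with compound 2 `CCCC(=O)C1=C(C)NC(=O)NC1c1cccs1` at 2% and close to compound 1 `CCCC(=O)C1=C(C)NC(=O)NC1c1ccco1` at 1%, so all three show very little inhibition at the tested concentration. Within the data shown here, the one measured step, a number 1 percentage points higher from compound 1 to compound 2 (within the scatter), lies within the scatter. Compound 4 `CCCC(=O)C1=C(C)NC(=O)NC1c1ccsc1` differs from compound 3 by propyl in place of cyclopropyl on a carbonyl carbon. Among the measured compounds shown here, no measured step touches this change, and the only guide is that compound 3, compound 2 and compound 1 all sit near zero inhibition. The expected step, no change at the digits printed from compound 3 to compound 4 (within the scatter), is none beyond the scatter. Compound 4 is therefore estimated to give 2% in this assay, with a range from -8% to 12%.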

Compound 4, a percentage reported as inhibition, at one concentration (the size of the read-out at that concentration, not a potency): 6%
The estimate for compound 4 lay 4 percentage points below the measured number; measured number inside the range.
By their numbers in this assay, from the lowest: compounds 1, 2, 3 and 4 (each within the scatter of the next).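

Measured in this assay the change from cyclopropyl to propyl on a carbonyl carbon gives a number 4 percentage points higher from compound 3 to compound 4 (within the scatter) and so shows that an open chain and a three-membered ring cannot be told apart at this position. The ring on the saturated carbon is no more telling, with thiophen-3-yl giving a number 4 percentage points higher from compound 2 to compound 4 (within the scatter) and a number 5 percentage points higher from compound 1 to compound 4 (within the scatter) as its two steps. No supporting data bear on these results.

All four compounds show little inhibition at this one concentration. From the compounds shown here alone, whether an amine or a longer chain on the carbonyl carbon would raise inhibition beyond the scatter stays open.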